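The compounds below may be only part of what the source reports. "The series", "measured", "known", "first", "only" and "open" are said of these compounds alone.

Compound 2 `COc1ccc(NC(=O)/C(C#N)=C/c2ccccc2C(F)(F)F)cc1` gives only a limit in an ADME assay on HBZY-1 cells (Rattus norvegicus) for cytotoxicity, read by MTT assay, with a stated time of 2 h (a lower number here means a stronger inhibitor, a higher number a weaker inhibitor), > 200000 nM. Compound 1 `COc1cc(NC(=O)/C(C#N)=C/c2ccccc2C(F)(F)F)cc(OC)c1OC` also gives only a limit, > 200000 nM. Compound 3 `CCCCNC(=O)/C(C#N)=C/c1ccccc1C(F)(F)F` does the same, with > 200000 nM. The set therefore rests on (the limit of > 200000 nM in this assay, at which 3 of the 3 values shown sit). Compound 4 `COc1ccc(NC(=O)/C(C#N)=C/c2ccccc2C(F)(F)F)cc1OC` differs from compound 2 by methoxy in place of hydrogen on an aromatic carbon, with methoxy in place of hydrogen on an aromatic carbon, ortho to a methoxy group. Within the data shown here, the only measured step that bears on this is a step that the two limits leave unreadable from compound 2 to compound 3, so it offers no size to carry over. No step beyond the scatter is expected in this assay, in either direction. The expected step is a step that the limit leaves unreadable from compound 2 to compound 4. For compound 4, the estimate is 250000 nM, with an expected range of 150000 nM to 500000 nM.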

Compound 4, half-maximal inhibitory concentration: > 200000 nM
Compound 4 gave a limit, no number; the forecaster's own chance of this, stated with the estimate: 90%; the middle value lies beyond the limit too.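

Among these compounds, compound 4, like compound 1 and compound 2, gives only a limit in this assay, so no step to compound 4 can be read. The compounds shown leave open how they rank against one another, because every value is a limit: the limit of > 200000 nM in this assay, at which 4 of the 4 values shown sit.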